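Halogenated benzylidene variation on a shared lactam core

This account rests on a few compounds, and the source may have more. Where it says the series, first, only, none or still open, it means among the compounds named here.

Compound 3 `O=C1/C(=C\c2cccc(Br)c2)c2ccccc2N1c1c(Cl)cccc1Cl` gives 2 ug/mL in a functional assay on KB cells (Homo sapiens) for cytotoxicity, read by MTT assay, with a stated time of 72 h; a lower number here means that less compound is needed, a higher number that more compound is needed for the effect. For the measured compounds named here, compound 2 `O=C1/C(=C\c2ccc(O)cc2)c2ccccc2N1c1c(Cl)cccc1Cl` gives 2 ug/mL, and no change at the digits printed from compound 2 to compound 3 (within the scatter); together these two hold the lowest numbers of the three measured so far. The furthest from compound 3 is compound 1 `O=C1/C(=C\c2c(Cl)cccc2Cl)c2ccccc2N1c1c(Cl)cccc1Cl`, which gives 50 ug/mL: a 25-fold lower number from compound 1 to compound 3 (1.40 log units; beyond the scatter), and in the same sense a 25-fold lower number from compound 1 to compound 2 (1.40 log units; beyond the scatter).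

Compound 4 `O=C1/C(=C\c2ccccc2Cl)c2ccccc2N1c1c(Cl)cccc1Cl` has not yet been measured. The change from compound 3 is 2-chlorophenyl in place of 3-bromophenyl on a double-bonded chain carbon bound to a double-bonded ring carbon. Going by the values given here, two measured steps bear on it. The step of a 25-fold lower number from compound 1 to compound 3 (1.40 log units; beyond the scatter) shows that moving away from 2,6-dichlorophenyl toward 3-bromophenyl lowers the number a great deal, while no change at the digits printed from compound 2 to compound 3 (within the scatter) shows that exchanging 4-hydroxyphenyl for 3-bromophenyl leaves it unchanged. The entering 2-chlorophenyl shares its chlorine-bearing phenyl with compound 1 rather than with compounds 2 and 3, so a move back toward the higher number of compound 1 is expected, though only part of the way.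

For compound 4 the estimated step is a 3.0-fold higher number from compound 3 to compound 4 (0.48 log units; beyond the scatter). The expected value for compound 4 in this assay is 6 ug/mL, with a range from 1.5 ug/mL to 25 ug/mL.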

Compound 4, concentration for half-maximal effect: 5 ug/mL
For compound 4 the middle estimate is 1.2-fold (0.08 log units) above the measured one; the measured number falls inside the stated range.
By their numbers in this assay, from the lowest: compounds 2 and 3 (each within the scatter of the next); then compound 4; then compound 1.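

In this assay, hydrogen in place of one chloro on the 2,6-dichlorophenyl of compound 1 gives a 10-fold lower number from compound 1 to compound 4 (1.00 log units; beyond the scatter) and so recovers much of the ground between the dichlorinated ring and the lowest numbers of the series, showing that the high number of compound 1 does not belong to every chlorine-bearing phenyl at this position. The single chlorine still leaves a gap beyond the scatter, with a 2.5-fold higher number from compound 3 to compound 4 (0.40 log units; beyond the scatter) and likewise a 2.5-fold higher number from compound 2 to compound 4 (0.40 log units; beyond the scatter) placing the 2-chlorophenyl of compound 4 between the two earlier levels. No measurement shown here gives a reason for either the recovery or the remaining gap.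

The step from 3-bromophenyl to 2-chlorophenyl changes both the halogen and its place on the ring, so these two contributions stay unseparated, and a 3-chlorophenyl or 2-bromophenyl at this position would be needed to tell them apart. Also open, on these data alone, is how this position would read with an amine or a carboxylic acid on the phenyl, or with the phenyl replaced by a longer chain.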